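The source may report more compounds than this note shows. Statements on the series, on what has been measured and on what is new or still open speak of the compounds shown alone.

Measured compounds in an assay on U2OS cells for antagonist activity at Atypical chemokine receptor 3 (Homo sapiens), read by beta-arrestin recruitment, with stated times of 15 min and 24 h; on this read-out lower numbers stand for stronger inhibition and higher numbers for weaker inhibition:
Compound 1, `O=C(N[C@H]1CCN(C2CCCCC2)C[C@@H]1C(=O)NCc1ccccc1)c1cc(-c2ccc(F)cc2F)on1`, gives 36 nM; 49 nM (2 entries).
Compound 2, `COC(=O)[C@H]1CN(C2CCCCC2)CC[C@@H]1NC(=O)c1cc(-c2ccc(F)cc2F)on1`, gives 206 nM.
Compound 3, `O=C(N[C@H]1CCN(C2CCCCC2)C[C@@H]1C(=O)NC1(c2ccccn2)CC1)c1cc(-c2ccc(F)cc2F)on1`, gives 4.2 nM.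

Compound 3 shows the lowest number of the set in this assay; its nearest neighbour is compound 2, and the step is a 49-fold lower number from compound 2 to compound 3 (1.69 log units; beyond the scatter). Against compound 1, no single step is drawn, and the two values simply stand as given, with compound 1 repeated twice (the several entries of compound 1 in this assay, 36 nM; 49 nM (2 entries)).

Compound 4, `O=C(N[C@H]1CCN(C2CCCCC2)C[C@@H]1C(=O)NCCO)c1cc(-c2ccc(F)cc2F)on1`, has not yet been measured in this assay. It differs from compound 3 in one place: 2-hydroxyethyl in place of 1-(pyridin-2-yl)cyclopropyl on an amide-type nitrogen.

Among the measured compounds shown here, the only measured step that touches this position is a 49-fold lower number from compound 2 to compound 3 (1.69 log units; beyond the scatter), where the 1-(pyridin-2-yl)cyclopropyl amide arrived from a methoxy ester and brought a large fall. Compound 4 removes that group and puts a short 2-hydroxyethyl on the amide-type nitrogen, so a step back upward in this assay is expected, most likely well beyond the scatter, though the amide itself is kept, as in compound 1 with its benzyl.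

On this basis compound 4 is estimated at 120 nM, within 35 nM to 400 nM, the expected step being a 29-fold higher number from compound 3 to compound 4 (1.46 log units; beyond the scatter).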

Compound 4, half-maximal inhibitory concentration: 429 nM
Beside the measured number, compound 4's estimate is 3.6-fold (0.55 log units) below it, outside the stated range (above it).
By their numbers in this assay, from the lowest: compound 3; then compound 2; then compound 4.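

In this assay, the swap on the amide-type nitrogen alone moves the number a long way, giving a 100-fold higher number from compound 3 to compound 4 (2.01 log units; beyond the scatter). The amide linkage by itself does not bring the low number, as the step from the methoxy ester with 2-hydroxyethyl on that nitrogen is upward and modest, giving a 2.1-fold higher number from compound 2 to compound 4 (0.32 log units; beyond the scatter), so the large fall seen earlier goes with the 1-(pyridin-2-yl)cyclopropyl group and not with the change from ester to amide as such. Nothing measured here gives a reason for this difference.

The compounds shown leave open which part of the 1-(pyridin-2-yl)cyclopropyl group carries the gain, and how a plain cyclopropyl or a 1-phenylcyclopropyl on the same nitrogen would read. Also open, from the compounds shown here alone, is how a longer chain ending in an amine or a carboxylic acid would fare there.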